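The source may report more compounds than this note shows. Statements on the series, on what has been measured and on what is new or still open speak of the compounds shown alone.

Measured so far in a functional assay on PC-12 cells (Rattus norvegicus) for cytotoxicity, read by MTT assay, with stated times of 2 h and 24 h, tested at 1 uM; on this read-out lower numbers stand for a weaker effect and higher numbers for a stronger effect at the one concentration tested:
compound 1 `Oc1cc(C(F)(F)F)ccc1-c1nc(-c2ccccc2O)n(-c2ccc(F)cc2)n1`, 67.2%
compound 2 `Oc1cc(C(F)(F)F)ccc1-c1nc(-c2ccccc2O)n(-c2ccc(Br)cc2)n1`, 69.4%

Going by the values given here, compound 2 holds the higher of the two numbers, but the single step between the two, a number 2.2 percentage points higher from compound 1 to compound 2 (within the scatter), is within the scatter, so the two values are not separable on this read-out and neither compound can be called the stronger.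

Compound 3 `Oc1cc(C(F)(F)F)ccc1-c1nc(-c2ccccc2O)n(-c2ccc(I)cc2)n1` has not yet been measured. Its change from compound 2 is iodo in place of bromo on an aromatic carbon. Among the compounds with values here, the only measured step that bears on it is the earlier halogen exchange at the same aromatic carbon, a number 2.2 percentage points higher from compound 1 to compound 2 (within the scatter), which stayed within the scatter. Within the data shown here, nothing among the measured compounds points to the further exchange for iodo behaving differently; the expected step in this assay is therefore none beyond the scatter, with no direction claimed.

On that basis compound 3 is estimated at 70%, with a range of 58% to 82%. The step this estimate implies, a number 0.6 percentage points higher from compound 2 to compound 3 (within the scatter), is expected to remain within the scatter.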

Compound 3, a percentage reported as activity, at one concentration (the size of the read-out at that concentration, not a potency): 70.1%
Compound 3: middle estimate off by 0.1 percentage points, on the low side; the range from low to high includes it.
By their numbers in this assay, from the lowest: compounds 1, 2 and 3 (each within the scatter of the next).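

In this assay the exchange of 4-bromophenyl for 4-iodophenyl gives a number 0.7 percentage points higher from compound 2 to compound 3 (within the scatter), and the exchange of fluoro for iodo at the same aromatic carbon gives a number 2.9 percentage points higher from compound 1 to compound 3 (within the scatter), so the second halogen step adds nothing that can be separated from the first. Going by these compounds alone, the earlier pair showed only one exchange, whereas the three compounds now show that fluoro, bromo and iodo on this carbon, para to a large group, cannot be told apart on this read-out, even when the two halogens furthest apart are compared directly. No evidence on the reason for this flat result is at hand.

On these data alone, whether the position stays as flat with a group that is not a halogen, such as an amine, a carboxylic acid or a longer chain, remains open. Also open, as far as these compounds go, is whether the shared core, with its two hydroxyl groups and its trifluoromethyl group, responds to change any more strongly than this halogen does, since all three compounds carry it unaltered.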